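Cytotoxicity notes on a small carboxylic acid series

The source may report more compounds than this note shows. Statements on the series, on what has been measured and on what is new or still open speak of the compounds shown alone.

Compound 1 `COc1cc(O)c(C(=O)O)c(C=Cc2ccc3ccccc3c2)c1` gives 65000 nM in an ADME assay on HEK293 cells (Homo sapiens) for cytotoxicity, read by resazurin assay, with a stated time of 24 h; on this read-out lower numbers stand for higher toxicity in this test and higher numbers for lower toxicity in this test.
Compound 2 `COc1cc(C=Cc2ccc3ccccc3c2)c(C(=O)O)c(OC)c1` gives only a limit in this assay, > 100000 nM.

Compound 2 therefore stands at a floor rather than a number. Among the compounds with values here, the single measured step, an at least 1.5-fold higher number from compound 1 to compound 2 (0.18 log units; that floor lies within the scatter), rests on (the limit of > 100000 nM in this assay, at which 1 of the 2 values shown sits). Compound 3 `COc1cccc(C=Cc2ccc3ccccc3c2)c1C(=O)O` is compound 2 with hydrogen in place of methoxy on an aromatic carbon. No measured step concerns this change; the one step shown alters a methyl on an oxygen and offers no guide. For compound 3 the expected step is a number no higher from compound 2 to compound 3 (the limit leaves the size open), none beyond the scatter. Compound 3 is estimated at 100000 nM, within 40000 nM to 300000 nM, most likely again reported as a limit.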

Compound 3, half-maximal cytotoxic concentration: > 100000 nM
Compound 3: no number, only a limit; the forecaster's own chance of this, stated with the estimate: 60%; the middle value sits exactly at the limit.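

No step from compound 2 to compound 3 can be read, since both stand at a limit in this assay: the limit of > 100000 nM in this assay, at which 2 of the 3 values shown sit.

The compounds shown leave open whether hydrogen in place of methoxy on an aromatic carbon changes the read-out at all.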